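The source may hold more compounds than are shown below. What is called first, only, known or untested is meant among the compounds shown, and "the series" means these compounds.

Compounds measured so far in a functional assay on MCF7 cells (Homo sapiens) for antiproliferative activity, read by sulforhodamine B assay, with a stated time of 72 h; a higher number here means a weaker inhibitor, a lower number a stronger inhibitor:
compound 1 `COc1ncc(-c2ccc3ncnc(Nc4ccc(OCCCO)nc4)c3c2)cc1NS(=O)(=O)c1ccc(F)cc1F`: 6120 nM
compound 2 `COC(=O)Cn1cc(Nc2ncnc3ccc(-c4cnc(OC)c(NS(=O)(=O)c5ccc(F)cc5F)c4)cc23)cn1`: 670 nM
compound 3 `COc1ncc(-c2ccc3ncnc(Nc4ccc(OCCO)c(Cl)c4)c3c2)cc1NS(=O)(=O)c1ccc(F)cc1F`: 3740 nM

Compound 1 gives the highest number of the three in this assay. Its nearest neighbour is compound 3: a 1.6-fold lower number from compound 1 to compound 3 (0.21 log units; within the scatter). The gap to compound 2 is larger: a 9.1-fold lower number from compound 1 to compound 2 (0.96 log units; beyond the scatter). Between compound 2 and compound 3 the difference is a 5.6-fold higher number from compound 2 to compound 3 (0.75 log units; beyond the scatter).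

Compound 4 `COc1ncc(-c2ccc3ncnc(Nc4ccc(OCCO)nc4)c3c2)cc1NS(=O)(=O)c1ccc(F)cc1F` is the next compound in the series and has not yet been measured. Relative to compound 1 the change is hydroxy in place of hydroxymethyl on a saturated chain carbon, two bonds along the chain from an oxygen on an aromatic ring, so the chain on the aromatic oxygen is one carbon shorter while the shared core and the sulfonamide side are untouched.

For the measured compounds named here, no measured step isolates this change. The step from compound 1 to compound 3 does contain the same shortening of the hydroxyalkoxy chain, but it comes together with a change of the ring that carries it and the addition of chlorine, and it stayed within the scatter. The two larger steps both involve a swap to the pyrazolyl group and do not speak to a chain-length change. The expectation for compound 4 is therefore a step of no more than the scatter in this assay, with no clear direction, a 1.2-fold lower number from compound 1 to compound 4 (0.09 log units; within the scatter). Compound 4 is expected to give about 5000 nM in this assay, within a range of 2300 nM to 11000 nM.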

Compound 4, half-maximal inhibitory concentration: 4300 nM
For compound 4 the middle estimate is 1.2-fold (0.07 log units) above the measured one; low and high end bracket the measured number.
By their numbers in this assay, from the lowest: compound 2; then compounds 3, 4 and 1 (each within the scatter of the next).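

In this assay, for the compounds shown here, replacing 3-hydroxypropoxy with 2-hydroxyethoxy on an otherwise unchanged compound gives the first isolated reading of this chain position, and the step stays within the scatter (a 1.4-fold lower number from compound 1 to compound 4 (0.15 log units; within the scatter)). With the 2-hydroxyethoxy chain held constant, the 6-(2-hydroxyethoxy)pyridin-3-yl and 3-chloro-4-(2-hydroxyethoxy)phenyl groups also do not separate (a 1.1-fold higher number from compound 3 to compound 4 (0.06 log units; within the scatter)), a comparison unavailable while chain and ring differed together. The 1-((methoxycarbonyl)methyl)-1H-pyrazol-4-yl group of compound 2 remains the only one set apart beyond the scatter, now also against the shorter-chain pyridinyl compound (a 6.4-fold higher number from compound 2 to compound 4 (0.81 log units; beyond the scatter)), and no supporting data bear on the reason for any of these steps.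

Still open, going by these compounds, is whether this position responds to anything other than a terminal hydroxy on a short chain, such as a terminal amine, a carboxylic acid or a longer chain like 4-hydroxybutoxy. Also open, on these data alone, is whether the gap seen with compound 2 belongs to the pyrazolyl ring or to its methyl ester, which a carboxylic acid or a 2-hydroxyethyl group on that ring would help to separate.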